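This account rests on a few compounds, and the source may have more. Where it says the series, first, only, none or still open, it means among the compounds named here.

Measured so far in a functional assay on the whole organism (strain Wistar) for inhibition, with Rattus norvegicus as the target, read by paw edema, with stated times of 30 min and 120 min, at a dose of 50 mg/kg by the oral route; on this read-out lower numbers stand for less inhibition and higher numbers for more inhibition at the one dose given (going by the name of the read-out):
Compound 1, `O=CN1N=C(c2ccc(F)cc2)CC1c1cn(-c2ccccc2)nc1-c1ccc(Cl)c(Cl)c1`, gives 60.9%.
Compound 2, `O=CN1N=C(c2ccc(Cl)cc2)CC1c1cn(-c2ccccc2)nc1-c1ccc(Cl)c(Cl)c1`, gives 57.8%.
Compound 3, `Cc1ccc(C2=NN(C=O)C(c3cn(-c4ccccc4)nc3-c3ccc(Cl)c(Cl)c3)C2)cc1`, gives 60.9%.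

Compound 2 cannot be set apart from its two companions: a number 3.1 percentage points lower from compound 1 to compound 2 (within the scatter) and a number 3.1 percentage points higher from compound 2 to compound 3 (within the scatter), and likewise no change at the digits printed from compound 1 to compound 3 (within the scatter), so the three numbers are indistinguishable. Compound 4, `CCC(=O)N1N=C(c2ccc(Cl)cc2)CC1c1cn(-c2ccccc2)nc1-c1ccc(Cl)c(Cl)c1`, is reached from compound 2 by ethyl in place of hydrogen on a carbonyl carbon. Within the data shown here, all three measured steps exchange a substituent on an aromatic carbon of a different ring and none touches the carbonyl, so no measured step bears directly on this change; what they do show is that small swaps stayed within the scatter. With no direct guide, the expected step is a number 0.2 percentage points higher from compound 2 to compound 4 (within the scatter), nothing beyond the scatter, held with wide uncertainty. Compound 4 is therefore estimated at 58% in this assay, with a range from 40% to 74%.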

Compound 4, a percentage reported as inhibition, in the whole organism at one dose (the size of the read-out at that dose, not a potency): 68.8%
For compound 4 the middle estimate is 10.8 percentage points below the measured one, and the stated range covers the measured number.
By their numbers in this assay, from the lowest: compounds 2, 1, 3 and 4 (each within the scatter of the next, the first and the last beyond it).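

Swapping formyl for propanoyl, with ethyl in place of hydrogen on a carbonyl carbon, gives a number 11 percentage points higher from compound 2 to compound 4 (beyond the scatter) in this assay. This carbonyl carbon on the amide-type nitrogen in a ring is therefore a place where a small addition moves the number past the scatter, unlike the earlier swaps on an aromatic carbon. No measurement shown here accounts for this step.

Still open, as far as these compounds go, is how acetyl or a longer chain such as butanoyl would compare with propanoyl here. Also open, from the compounds shown here alone, is whether ethyl gives a similar step with fluoro or methyl in place of chloro.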